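Series notes: ether substituent on the aryl of the shared core

The compounds below may be only part of what the source reports. "The series", "measured", "known", "first", "only" and "open" are said of these compounds alone.

Measured so far:
- compound 1, `CCN(CC)C(=O)Cc1c(-c2ccc(OC3CCC3)cc2)nn2c(C)cc(C)nc12`: 0.86 nM
- compound 2, `CCN(CC)C(=O)Cc1c(-c2ccc(OCC3CCCCC3)cc2)nn2c(C)cc(C)nc12`: 3.6 nM

Both compounds were read in an assay on isolated protein (kidney, strain Wistar) for displacement of a labelled ligand from Translocator protein (Rattus norvegicus), read by scintillation counting, with a stated time of 90 min; a lower number here means a stronger inhibitor, a higher number a weaker inhibitor. Compound 2 has the higher of the two numbers; the one step shown, a 4.2-fold higher number from compound 1 to compound 2 (0.62 log units; beyond the scatter), is the only measured change in this series, and it concerns the group on the oxygen on the aromatic ring.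

The next compound, compound 3, `CCN(CC)C(=O)Cc1c(-c2ccc(OCc3cccc(C(F)(F)F)c3)cc2)nn2c(C)cc(C)nc12`, keeps the chain of compound 2 and alters only its end: 3-(trifluoromethyl)phenyl in place of cyclohexyl on a saturated chain carbon bound to an oxygen on an aromatic ring. Within the data shown here, no measured step exchanges a saturated ring for an aromatic one at this place, so the one step from compound 1 to compound 2 bears on it only in showing that the ether substituent does move the number by a modest amount. Among the measured compounds shown here, with no direct precedent, the expected step of a 1.1-fold higher number from compound 2 to compound 3 (0.05 log units; within the scatter) is taken as small, in either direction, and possibly within the scatter. Compound 3 is therefore estimated at 4 nM in this assay, with a range of 1.5 nM to 12 nM.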

Compound 3, inhibition constant: 0.67 nM
For compound 3 the middle estimate is 6.0-fold (0.78 log units) above the measured one, outside the stated range (below it).
By their numbers in this assay, from the lowest: compounds 3 and 1 (each within the scatter of the next); then compound 2.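

In this assay, the end of the chain at this place can move the number in either direction: a 5.4-fold lower number from compound 2 to compound 3 (0.73 log units; beyond the scatter) is beyond the scatter, and it runs opposite to a 4.2-fold higher number from compound 1 to compound 2 (0.62 log units; beyond the scatter). The higher number of compound 2 therefore belongs to cyclohexylmethyl and not to every ring-bearing group on a saturated chain carbon, since a 1.3-fold lower number from compound 1 to compound 3 (0.11 log units; within the scatter) lies within the scatter despite the exchange of cyclobutyl for 3-(trifluoromethyl)benzyl. Nothing available gives a reason for the difference between the saturated and the aromatic ring at this place.

The compounds shown cannot divide the step to 3-(trifluoromethyl)phenyl between the aromatic ring and the trifluoromethyl group, a split that plain benzyl would address. As far as these compounds go, whether the same result holds with a longer chain, as in phenethyl, also remains open.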